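The compounds below may be only part of what the source reports. "The series", "measured", "known", "first", "only" and "open" are said of these compounds alone.

Compound 1 `CCCS(=O)(=O)Nc1cccc2c1CCC2c1ncc[nH]1` gives 1340 nM in a functional assay on CHO cells for agonist activity at Alpha-1A adrenergic receptor (Homo sapiens), read by FLIPR and calcium flux; a lower number here means that less compound is needed, a higher number that more compound is needed for the effect.
Compound 2 `Cc1oncc1-c1cccc2c1CCC2c1ncc[nH]1` gives 111 nM in this assay.

Compound 2 stands at the lower of the two numbers. For the measured compounds named here, the single measured step, a 12-fold lower number from compound 1 to compound 2 (1.08 log units; beyond the scatter), concerns a different exchange, so no measured step bears directly on the next change. Compound 3 `Cn1cc(-c2cccc3c2CCC3c2ncc[nH]2)cn1` differs from compound 2 by 1-methyl-1H-pyrazol-4-yl in place of 5-methyl-1,2-oxazol-4-yl on an aromatic carbon. Going by the values given here, one five-membered aromatic ring replaces another of the same size, and with no comparable step known, the expectation for compound 3 is a 1.4-fold higher number from compound 2 to compound 3 (0.13 log units; within the scatter), nothing beyond the scatter. Compound 3 is thus estimated at 150 nM, in a range from 50 nM to 500 nM.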

Compound 3, half-maximal effective concentration: > 2900 nM
Compound 3: only a limit was reported; the forecaster's own chance of this, stated with the estimate: 3%; middle value at least 19-fold (1.28 log units) from the limit.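

The value for compound 3 is a limit of the assay, not a number: the limit of > 2900 nM in this assay, at which 1 of the 3 values shown sits. Even so, exchanging one five-membered aromatic ring for another on this aromatic carbon gives an at least 26-fold higher number from compound 2 to compound 3 (1.41 log units; beyond the scatter), although the two groups have the same counts of heavy atoms, hetero atoms, hydrogen-bond donors and acceptors, so those counts do not separate them. A five-membered aromatic ring alone is therefore not enough for a lower number, as the 1-methyl-1H-pyrazol-4-yl group gives an at least 2.1-fold higher number from compound 1 to compound 3 (0.33 log units; beyond the scatter).

The compounds shown leave open whether the ring oxygen or the position of the methyl group accounts for the gap. A 1,2-oxazol-4-yl group without the methyl, or a plain phenyl ring, would help to separate these possibilities.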